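The source may hold more compounds than are shown below. What is called first, only, known or untested is meant among the compounds shown, and "the series" means these compounds.

Working notes on the series. Compound 1 has the structure `CCCCC(C)C/C(=C\[C@@]1(CC)OC(=O)C[C@@H]1O)CC`. In a functional assay on A549 cells (Homo sapiens) for cytotoxicity, read by MTT assay, with a stated time of 72 h (a lower number here means a stronger inhibitor, a higher number a weaker inhibitor), compound 1 reaches only the limit of > 100000 nM, which is a limit of the assay and not a number.

Compound 2, `CCCCC(CC)CC(O)(/C=C(/CC)[C@@H](O)CC(=O)OC)CC`, is the open-chain ester of the pair. In this assay compound 2 gives 23600 nM. Within the data shown here, this is the only number in the set; the other value is a limit, (the limit of > 100000 nM in this assay, at which 1 of the 2 values shown sits). Compound 2 therefore stands as the sole measured point from which anything can be read.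

Compound 3, `CCCCC(C)CC(O)(/C=C(/CC)[C@@H](O)CC(=O)OC)CC`, is still to be measured. It differs from compound 2 by hydrogen in place of methyl on a saturated chain carbon, four bonds along the chain from a double-bonded chain carbon and an oxygen on a saturated carbon. Among the measured compounds shown here, no step between two measured compounds is available, so the set itself says nothing about how a change of this kind moves the number. The loss of a methyl from a saturated chain carbon is the whole of the change, and the expected step is none beyond the scatter, a 1.3-fold higher number from compound 2 to compound 3 (0.10 log units; within the scatter). For compound 3 the estimate in this assay is 30000 nM, with a range from 9000 nM to 100000 nM.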

Compound 3, half-maximal inhibitory concentration: 29300 nM
Estimate against measurement, compound 3: 1.0-fold (0.01 log units) above; the measured number falls inside the stated range.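

In this assay, hydrogen in place of methyl on a saturated chain carbon, four bonds along the chain from a double-bonded chain carbon and an oxygen on a saturated carbon, gives a 1.2-fold higher number from compound 2 to compound 3 (0.09 log units; within the scatter). Among these compounds, this is the first step that can be read between two measured compounds, and it shows that, in this open-chain ester, cutting ethyl to methyl at this position leaves the number within the scatter; one pair shows this for this change alone and sets no rule for the position. Nothing on hand gives a cause for this step.

As far as these compounds go, whether a longer chain, a hydroxyl, an amine or a carboxylic acid at this position would move the number beyond the scatter stays open. Among the compounds shown here, compound 1 stands at > 100000 nM, a limit of the assay and not a number, so no step to or from compound 1 can be read.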